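The source may report more compounds than this note shows. Statements on the series, on what has been measured and on what is new or still open speak of the compounds shown alone.

Compound 2, with structure `CCCSc1nsnc1C1CN2CCC[C@H]1C2`, gives 0.056 mg/kg in a functional assay on the whole organism for inhibition, with Rattus norvegicus as the target; a higher number here means that more compound is needed for the effect, a lower number that less compound is needed. Among the two compounds measured, compound 2 carries the higher number, though its nearest neighbour compound 1, with structure `CCSc1nsnc1C1CN2CCC[C@H]1C2`, gives 0.045 mg/kg in this assay, and the step of a 1.2-fold higher number from compound 1 to compound 2 (0.09 log units; within the scatter) stays within the scatter. Compound 3, with structure `CCCSc1nsnc1[C@@H]1CN2CCC[C@H]1C2`, is the next one to be measured. The difference is the two compounds have the same atoms and bonds; at least one stereo element is drawn with a configuration in one of them and without one in the other: 1 of 3 stereo elements differ; a stereocentre at a saturated ring carbon is drawn without a configuration in compound 2 and S in compound 3: the two compounds have the same atoms and bonds, and only the drawing of one stereocentre at a saturated ring carbon differs, unspecified in compound 2 and S in compound 3. For the measured compounds named here, no measured step touches such a change; the only step known, from compound 1 to compound 2, concerns a methyl on the chain and is within the scatter. The expected step of a 1.2-fold lower number from compound 2 to compound 3 (0.09 log units; within the scatter) is therefore small, with a wide range. Compound 3 is estimated at 0.045 mg/kg, between 0.015 mg/kg and 0.15 mg/kg.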

Compound 3, dose for half-maximal effect: 0.03 mg/kg
Beside the measured number, compound 3's estimate is 1.5-fold (0.18 log units) above it, and the stated range covers the measured number.
By their numbers in this assay, from the lowest: compounds 3, 1 and 2 (each within the scatter of the next).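

The earlier compounds shown here varied only the chain and said nothing about the spatial arrangement at this saturated ring carbon. Drawing this stereocentre as S gives a 1.9-fold lower number from compound 2 to compound 3 (0.27 log units; within the scatter) in this assay, so here the defined form cannot be told apart from the form without a drawn configuration. The comparison therefore rests on a difference in how the structures are specified, not in their atoms or bonds: the fact that one of compounds 2 and 3 is drawn with a defined configuration and the other without, at the place where they differ

The drawing of compound 2 does not say whether it is a single form or a mixture, and the compounds shown include none with the opposite configuration at this carbon, so the importance of this stereocentre remains unknown. Also open, from the compounds shown here alone, is whether the same picture would hold with a longer chain, such as butyl, on the sulfur.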